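This account rests on a few compounds, and the source may have more. Where it says the series, first, only, none or still open, it means among the compounds named here.

Of the compounds shown here, three built on one shared core have been tested in a functional assay on COLO 205 cells (Homo sapiens) for cytotoxicity, read by MTT assay, with a stated time of 24 h; a lower number here means a stronger inhibitor, a higher number a weaker inhibitor. Compound 1 `Fc1ccc(-n2cc(COc3ccccc3-c3nc4ccccc4s3)nn2)cc1Cl` gives 14400 nM. Compound 3 `Fc1ccc(-n2cc(COc3ccccc3-c3nc4ccccc4s3)nn2)cc1` differs from compound 1 by hydrogen in place of chloro on an aromatic carbon; in this assay compound 3 gives 18900 nM, and the step of a 1.3-fold higher number from compound 1 to compound 3 (0.12 log units; within the scatter) lies within the scatter of repeated measurements. Compound 2 `FC(F)(F)Oc1ccc(-c2cc(COc3ccccc3-c3nc4ccccc4s3)on2)cc1`, whose core differs from the other two, gives 19900 nM. Among these three numbers compound 3 stands second highest, with compound 2 nearest and compound 1 furthest, and all three values lie within the scatter of one another.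

Compound 4 `FC(F)(F)c1cccc(-n2cc(COc3ccccc3-c3nc4ccccc4s3)nn2)c1` has not yet been measured. It differs from compound 3 by 3-(trifluoromethyl)phenyl in place of 4-fluorophenyl on an aromatic nitrogen. Going by the values given here, the only measured step that alters a group on this same phenyl ring, a 1.3-fold higher number from compound 1 to compound 3 (0.12 log units; within the scatter), stayed within the scatter. Among the compounds with values here, no measured pair involves a trifluoromethyl group, so the expectation rests on that single step alone. Compound 4 is therefore expected to give about 19000 nM, with a likely range from 8000 nM to 45000 nM, a step of a 1.0-fold higher number from compound 3 to compound 4 (0.00 log units; within the scatter) that is expected to stay within the scatter.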

Compound 4, half-maximal inhibitory concentration: 10800 nM
Estimate against measurement, compound 4: 1.8-fold (0.25 log units) above; the measured number falls inside the stated range.
By their numbers in this assay, from the lowest: compounds 4, 1, 3 and 2 (each within the scatter of the next).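

In this assay, going by these compounds alone, the earlier compounds showed only the loss of a chloro group from the phenyl ring on the aromatic nitrogen, whereas this result replaces the ring's substitution altogether. Exchanging 4-fluorophenyl for the larger 3-(trifluoromethyl)phenyl gives a 1.8-fold lower number from compound 3 to compound 4 (0.24 log units; within the scatter), and exchanging 3-chloro-4-fluorophenyl for it gives a 1.3-fold lower number from compound 1 to compound 4 (0.12 log units; within the scatter), so all three phenyl groups on this nitrogen give numbers within the scatter of one another. Nothing available here explains why these numbers lie so close together.

As far as these compounds go, it remains open whether this position would stay as insensitive with a phenyl ring carrying an amine or a carboxylic acid, or with a longer chain in place of the ring. The compounds shown also cannot say whether any change at this position would take the numbers beyond the scatter.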